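Thiophen-2-yl to methyl: notes on the shared core

The source may report more compounds than this note shows. Statements on the series, on what has been measured and on what is new or still open speak of the compounds shown alone.

Measured in a functional assay on the whole organism (stomach) for inhibition, with Rattus norvegicus as the target, at a dose of 100 mg/kg by the intraduodenal route; on this read-out lower numbers stand for less inhibition and higher numbers for more inhibition at the one dose given (going by the name of the read-out):
compound 1 `N=C(S)CCN1N=C(c2cccs2)CCC1=O` gives 58.5%
compound 2 `CC(Cn1ncccc1=S)C(=N)S` gives -1%
compound 3 `N=C(S)CCCCCN1N=C(c2ccccc2)CCC1=O` gives 48.5%

Compound 1 has the highest of the three numbers in this assay. Its nearest neighbour is compound 3, whose number lies within the scatter of compound 1, so no order between the two can be claimed. Compound 2, with a different core, lies far below compound 1, beyond the scatter.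

Compound 4 `CC1=NN(CCC(=N)S)C(=O)CC1` is still unmeasured. It differs from compound 1 by methyl in place of thiophen-2-yl on a carbon with a double bond to nitrogen. For the measured compounds named here, no step between measured compounds shows what this exchange does; the only guide is that both compounds 1 and 3 carry an aromatic group at this position. A drop, possibly beyond the scatter, is expected. The expected step is a number 23.5 percentage points lower from compound 1 to compound 4 (beyond the scatter). For compound 4 the estimated value in this assay is 35%, with a range from 10% to 58%.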

Compound 4, a percentage reported as inhibition, in the whole organism at one dose (the size of the read-out at that dose, not a potency): 34.8%
The estimate for compound 4 lay 0.2 percentage points above the measured number; the measured number falls inside the stated range.
By their numbers in this assay, from the lowest: compound 2; then compound 4; then compounds 3 and 1 (each within the scatter of the next).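

In this assay, for the compounds shown here, methyl in place of thiophen-2-yl gives a number 23.7 percentage points lower from compound 1 to compound 4 (beyond the scatter) and so provides the first readable step at this position of the shared core. Compound 4 at 34.8% retains inhibition at the one dose given, so an aromatic ring at this position is not required for a positive read-out, although the exchange lowers the number. Nothing available bears on the reason for this step.

Going by these compounds, how an amine or a cyclohexyl group would compare at this position remains open. On these data alone, whether the step holds with a longer chain on the ring nitrogen also remains open.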